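This account rests on a few compounds, and the source may have more. Where it says the series, first, only, none or still open, it means among the compounds named here.

Compound 3 `C/C(=N\NC(N)=S)c1ccc2c(c1)nc(-c1ccc(C(F)(F)F)cc1)n2C1CCCCC1` gives > 100000 nM in an ADME assay on Vero cells (Chlorocebus sabaeus) for cytotoxicity, read by MTT assay, with a stated time of 96 h (on this read-out lower numbers stand for higher toxicity in this test and higher numbers for lower toxicity in this test), which is a limit of the assay and not a number. Compound 1 `COc1ccc(-c2nc3cc(/C(C)=N/NC(N)=S)ccc3[nH]2)cc1` gives > 100000 nM, which is also a limit. The top of the scale is therefore capped by the limit of > 100000 nM in this assay, at which 2 of the 3 values shown sit.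

Compound 4 `COc1ccc(-c2nc3cc(/C(C)=N/NC(N)=S)ccc3n2C2CCCCC2)cc1` changes one group of compound 3: methoxy in place of trifluoromethyl on an aromatic carbon, para to a large group (methoxy in place of trifluoromethyl on an aromatic carbon).

Among the compounds with values here, one measured step bears on this carbon. Compound 2 `C/C(=N\NC(N)=S)c1ccc2c(c1)nc(-c1ccccc1)n2C1CCCCC1` has hydrogen there and gives 20000 nM. Putting trifluoromethyl on that carbon gives an at least 5.0-fold higher number from compound 2 to compound 3 (0.69 log units; beyond the scatter). Within the data shown here, no measured step shows what methoxy does at this place. With the trifluoromethyl gone, compound 4 may fall back toward compound 2, at 20000 nM, though probably not all the way. Compound 4 could even stay at the limit. The estimated step is an at least 2.2-fold lower number from compound 3 to compound 4 (0.34 log units; beyond the scatter), towards a lower number and so towards more toxicity in this test. For compound 4 the expected value is 45000 nM, with an estimated range of 15000 nM to 100000 nM.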

Compound 4, half-maximal cytotoxic concentration: 40000 nM
The estimate for compound 4 lay 1.1-fold (0.05 log units) above the measured number, and the stated range covers the measured number.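

Methoxy in place of trifluoromethyl on this aromatic carbon gives an at least 2.5-fold lower number from compound 3 to compound 4 (0.39 log units; beyond the scatter), so in this assay the high number of compound 3 is not shared by the methoxy group. Methoxy in place of hydrogen gives a 2.0-fold higher number from compound 2 to compound 4 (0.30 log units; within the scatter), which is within the usual scatter, so methoxy on this carbon cannot be told apart from hydrogen. The nitrogen also gets its first measured step, as cyclohexyl in place of hydrogen gives an at least 2.5-fold lower number from compound 1 to compound 4 (0.39 log units; beyond the scatter).

The true size of the steps involving compound 1 and compound 3 stays open, as both compounds give only limits: the limit of > 100000 nM in this assay, at which 2 of the 4 values shown sit. The compounds shown also leave open whether a chlorine atom or a dimethylamino group on this carbon would read like trifluoromethyl or like methoxy.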